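The source may report more compounds than this note shows. Statements on the series, on what has been measured and on what is new or still open speak of the compounds shown alone.

Measured so far in a functional assay on K562 cells (Homo sapiens) for antiproliferative activity, read by MTT assay, with a stated time of 72 h; on this read-out lower numbers stand for stronger inhibition and higher numbers for weaker inhibition:
compound 1 `COc1cc(-c2ncnn2-c2cccc(N)c2)cc(OC)c1OC` — > 10000 nM
compound 2 `COc1cc(-n2ncnc2-c2cccc(F)c2)cc(OC)c1OC` — > 10000 nM

Compound 2 stands at a limit of this assay, not at a number. Compound 1 likewise gives only a limit. For the measured compounds named here, both readings sit at the limit of > 10000 nM in this assay, at which 2 of the 2 values shown sit, so no step between measured compounds can be read, and the two cannot be ordered against each other.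

Compound 3 `COc1cccc(-c2ncnn2-c2cc(OC)c(OC)c(OC)c2)c1` is not yet measured in this assay. It differs from compound 2 by methoxy in place of fluoro on an aromatic carbon: fluoro leaves, methoxy enters; cut one bond further out, the change reads 3-fluorophenyl to 3-methoxyphenyl. With both measured values at the limit, nothing in this pair shows any change moving potency; the step to compound 3 is expected to be none beyond the scatter, most likely returning a limit again. For compound 3 the estimate is 15000 nM, range 3000 nM to 60000 nM. The step that the limit leaves unreadable from compound 2 to compound 3 is thus expected.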

Compound 3, half-maximal inhibitory concentration: > 10000 nM
Compound 3 was reported as a limit; the forecaster's own chance of this, stated with the estimate: 70%; the middle value does not contradict the limit.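

No step can be read from compound 2 to compound 3, since both give only a limit: the limit of > 10000 nM in this assay, at which 3 of the 3 values shown sit.

The compounds shown leave open whether any change on the shared core gives a measurable value in this assay, and how the 3-fluorophenyl and 3-methoxyphenyl compounds would order.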